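The compounds below may be only part of what the source reports. "The series", "measured", "known", "first", "only" and "open" are said of these compounds alone.

Compound 1 `NC(=O)CCNC(=O)c1ccc([C@H]2[C@@H](F)[C@@H](F)C[C@@H](F)[C@H]2F)cc1` gives 0.4 10^-6 cm/s in an ADME assay on MDCK-MDR1 cells (Canis lupus familiaris) for permeability, in the apical to basolateral direction, with a stated time of 180 min; on this read-out higher numbers stand for higher permeability and lower numbers for lower permeability.
Compound 2 `O=C(c1ccc([C@H]2[C@@H](F)[C@@H](F)C[C@@H](F)[C@H]2F)cc1)N1CC(O)C1` gives 6.7 10^-6 cm/s in this assay.

Going by the values given here, compound 2 stands highest of the two measured numbers in this assay; the only other compound, compound 1, lies far below it, as the step of a 17-fold higher number from compound 1 to compound 2 (1.22 log units; beyond the scatter) shows. Compound 3 `O=C(NCc1cc[nH]n1)c1ccc([C@H]2[C@@H](F)[C@@H](F)C[C@@H](F)[C@H]2F)cc1` has not been measured. It differs from compound 2 in one place: ((1H-pyrazol-3-yl)methyl)amino in place of 3-hydroxyazetidin-1-yl on a carbonyl carbon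

Among the compounds with values here, the one measured step bears on this change only partly: it was large, and it came when a ring nitrogen joined the carbonyl in place of an amino-linked chain. Going from compound 2 to compound 3 puts an amino-linked group back on the carbonyl, though a different one from that of compound 1. A step downward beyond the scatter is therefore expected, likely smaller than the step from compound 1 to compound 2, giving a 3.4-fold lower number from compound 2 to compound 3 (0.53 log units; beyond the scatter). For compound 3 the estimated value is 2 10^-6 cm/s, expected to fall between 0.6 10^-6 cm/s and 6 10^-6 cm/s.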

Compound 3, apparent permeability: 2.1 10^-6 cm/s
Compound 3: middle estimate off by 1.1-fold (0.02 log units), on the low side; measured number inside the range.
By their numbers in this assay, from the lowest: compound 1; then compound 3; then compound 2.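

In this assay, the group on the carbonyl carbon can be amino-linked and still give a mid-range number: the ((1H-pyrazol-3-yl)methyl)amino group of compound 3 gives a 3.2-fold lower number from compound 2 to compound 3 (0.50 log units; beyond the scatter), yet the end of the chain also matters, with a 5.3-fold higher number from compound 1 to compound 3 (0.72 log units; beyond the scatter). Among these three compounds, the number therefore depends on more than whether the group is attached through a ring nitrogen or an amino link, since the two amino-linked compounds differ clearly, while 3-hydroxyazetidin-1-yl in compound 2 still gives the highest number. Nothing shown here explains why either step takes the size it does.

On these data alone, it remains open whether a phenyl ring or an imidazole ring at the end of the chain would behave like the pyrazole. As far as these compounds go, it is also open whether the hydroxyl matters, which a plain azetidine on the carbonyl would test.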